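A few compounds are considered here, and "the series" means these few. Any claim that something is new, unique, unknown or untested is made for them only; others in the source may bear on it.

Measured so far:
Compound 1 `COc1ccc(/C=C/C(=O)/C=C/c2ccc(OCc3cn(CCCCOc4cc(=O)oc5ccccc45)nn3)c(OC)c2)cc1OC`: 55%
Compound 2 `COc1cccc(/C=C/C(=O)/C=C/c2ccc(OCc3cn(CCOc4cc(=O)oc5ccccc45)nn3)c(OC)c2)c1`: 70%
Compound 3 `COc1ccc(/C=C/C(=O)/C=C/c2ccc(OCc3cn(CCCOc4cc(=O)oc5ccccc45)nn3)c(OC)c2)cc1`: 54%

These three compounds were tested in a functional assay on HCT-116 cells (Homo sapiens) for inhibition, read by sulforhodamine B assay, with a stated time of 48 h, tested at 50 uM; on this read-out lower numbers stand for less inhibition of growth and higher numbers for more inhibition of growth at the one concentration tested. In this small set, compound 1 at 55% lies within the scatter of compound 3 at 54%. Compound 2 at 70% stands higher than compound 1, and that gap lies beyond the scatter.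

The next compound to be examined is compound 4 `COc1cc(/C=C/C(=O)/C=C/c2cccs2)ccc1OCc1cn(CCCCOc2cc(=O)oc3ccccc23)nn1`, which is derived from compound 1 by a single structural change. It carries thiophen-2-yl in place of 3,4-dimethoxyphenyl on a double-bonded chain carbon bound to a double-bonded chain carbon. The rest of the structure of compound 1 is kept.

Within the data shown here, no two measured compounds differ in only one place, so the data give no direct measure of what such a replacement does in this assay. The expectation therefore rests on compound 1 at 55%, with a wide margin, and no step beyond the scatter is expected in either direction. The expected change is small, a number 3 percentage points higher from compound 1 to compound 4 (within the scatter). Compound 4 is estimated at 58%, with an expected range from 42% to 74%.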

Compound 4, percent growth inhibition at one concentration: 41%
Beside the measured number, compound 4's estimate is 17 percentage points above it; the measured number lies below the stated range.
By their numbers in this assay, from the lowest: compound 4; then compounds 3 and 1 (each within the scatter of the next); then compound 2.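

In this assay, among these compounds, thiophen-2-yl in place of 3,4-dimethoxyphenyl on a double-bonded chain carbon bound to a double-bonded chain carbon gives a number 14 percentage points lower from compound 1 to compound 4 (beyond the scatter), and this is the only single change in the set whose effect can be read. It shows that this position is not indifferent to the group it carries: exchanging one six-membered aromatic ring of carbon only for one five-membered aromatic ring with 1 hetero atom, with the rest of compound 1 kept, goes with less inhibition of growth at the one concentration tested. No measurement at hand accounts for the difference.

The swap alters the ring and removes both methoxy groups at once, so a plain phenyl, a 4-methoxyphenyl or a furan-2-yl at this place would be needed to tell these parts apart. Among the compounds shown here, it also remains open whether the same replacement would give a similar step on the linking chains of compound 2 and compound 3, since no step starting from either of them can be read.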